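Trimming One Methoxy Group from Compound 2

The compounds below may be only part of what the source reports. "The series", "measured", "known", "first", "only" and "open" are said of these compounds alone.

Among the compounds with values here, two related compounds have numbers so far. In a functional assay on CNE-2 cells (Homo sapiens) for cytotoxicity, read by sulforhodamine B assay, with a stated time of 48 h (on this read-out higher numbers stand for weaker inhibition and lower numbers for stronger inhibition), compound 1 `COc1cc(/C=C/C(=O)c2cccc(-c3cccc(F)c3)c2)ccc1O` gives 5690 nM, and compound 2 `COc1cccc(/C=C/C(=O)c2cccc(-c3cccc(F)c3)c2)c1OC` gives 10000 nM. These two numbers lie within the usual scatter of repeated measurements, so compound 2 stands level with compound 1, and neither can be ranked against the other.

The next structure, compound 3 `COc1ccccc1/C=C/C(=O)c1cccc(-c2cccc(F)c2)c1`, is compound 2 with a single change: hydrogen in place of methoxy on an aromatic carbon. Within the data shown here, no measured pair here differs by this change alone, so the data give no direct guide to its size. The only hint is indirect. Compound 1 at 5690 nM and compound 2 at 10000 nM carry different groups on that ring, yet their numbers stay within the scatter, so a large swing seems unlikely here too.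

The expected change is a 1.3-fold lower number from compound 2 to compound 3 (0.10 log units; within the scatter), which is no step beyond the scatter and has no firm direction. In this assay the estimate for compound 3 is 8000 nM, with an expected range from 3000 nM to 20000 nM.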

Compound 3, half-maximal inhibitory concentration: 10400 nM
Compound 3: middle estimate off by 1.3-fold (0.11 log units), on the low side; low and high end bracket the measured number.
By their numbers in this assay, from the lowest: compounds 1, 2 and 3 (each within the scatter of the next).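

Within the data shown here, compound 3 gives the first direct reading of hydrogen in place of methoxy on an aromatic carbon: in this assay, the step is a 1.0-fold higher number from compound 2 to compound 3 (0.02 log units; within the scatter), so the two compounds stand level. Compound 1 and compound 2 differ in more than one place on that ring and could only hint at this, whereas this pair isolates a single position, ortho to a methoxy group and meta to a large group, and shows that the methoxy group there can be lost with no measurable effect on the number in this cell assay. There is no outside information that would explain this result, so the finding stands as a plain observation.

From the compounds shown here alone, whether a different group on the same aromatic carbon, such as an amine, a carboxylic acid or a longer ether chain, would also leave the number level remains open. Compound 3 still carries one methoxy group on this ring, and what would happen if hydrogen replaced that one as well is also an open question.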